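The source may hold more compounds than are shown below. What is called first, only, known or untested is meant among the compounds shown, and "the series" means these compounds.

In a functional assay on HCT-15 cells (Homo sapiens) for cytotoxicity, read by CCK-8 assay and cell counting, with a stated time of 2 days (a higher number here means a weaker inhibitor, a lower number a stronger inhibitor), three compounds have been measured:

Compound 1 `Oc1cccc(-c2cc(-c3ccc(Cl)cc3)nc(-c3cccs3)c2)c1`: 9280 nM
Compound 2 `Oc1ccc(-c2cc(-c3ccc(Cl)cc3)nc(-c3ccsc3)c2)cc1`: 6240 nM
Compound 3 `Oc1cccc(-c2cc(-c3cccs3)nc(-c3ccccc3Cl)c2)c1`: 2790 nM

Compound 3 differs from compound 1 by one change, (2-chlorophenyl in place of 4-chlorophenyl on an aromatic carbon), and that change gave a 3.3-fold lower number from compound 1 to compound 3 (0.52 log units; beyond the scatter). Compound 2 and compound 1 share the same atoms joined differently, but the difference between the two cores is not broken down here; their values lie within the usual scatter of each other.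

Compound 4 `Oc1ccc(-c2cc(-c3ccsc3)nc(-c3ccccc3Cl)c2)cc1` is not yet measured in this assay. It differs from compound 2 by 2-chlorophenyl in place of 4-chlorophenyl on an aromatic carbon. This is the same kind of change as from compound 1 to compound 3, though its surroundings differ: here the place is meta to a 4-hydroxyphenyl group and meta to a thiophen-3-yl group, whereas before it was meta to a 3-hydroxyphenyl group and meta to a thiophen-2-yl group. Because that earlier change gave a 3.3-fold lower number from compound 1 to compound 3 (0.52 log units; beyond the scatter), a step of about a 2.7-fold lower number from compound 2 to compound 4 (0.43 log units; beyond the scatter) is expected from compound 2 to compound 4, with added uncertainty since it rests on a single example in a different setting. Compound 4 is therefore estimated at 2300 nM, likely between 900 nM and 6000 nM.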

Compound 4, half-maximal inhibitory concentration: 5830 nM
The estimate for compound 4 lay 2.5-fold (0.40 log units) below the measured number; the measured number falls inside the stated range.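

In this assay putting 2-chlorophenyl in place of 4-chlorophenyl gave a 1.1-fold lower number from compound 2 to compound 4 (0.03 log units; within the scatter) on the core of compound 2, so here the swap has no clear effect. Set beside the earlier case, the change does not carry over from one core to the other with the same size: the same change on two cores in this assay, a 3.3-fold lower number (0.52 log units; beyond the scatter) from compound 1 to compound 3 and a 1.1-fold lower number (0.03 log units; within the scatter) from compound 2 to compound 4, 3.1-fold (0.49 log units) apart, beyond the scatter of two such steps. Going by these compounds alone, with only two examples, and with the two cores differing in both the hydroxyphenyl and the thiophene groups, this does not show which of those differences matters or why.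

Still open, from the compounds shown here alone, is how the swap behaves with the 3-hydroxyphenyl group paired with the thiophen-3-yl group, or the 4-hydroxyphenyl group with the thiophen-2-yl group. Also open, going by these compounds, is what an amine or a carboxylic acid in place of the hydroxyl would do.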